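Losing the triple bond from compound 1

The compounds below may be only part of what the source reports. "The series", "measured", "known", "first", "only" and "open" are said of these compounds alone.

In a functional assay on MCF7 cells (Homo sapiens) for antiproliferative activity, read by MTT assay, with a stated time of 24 h (on this read-out lower numbers stand for stronger inhibition and higher numbers for weaker inhibition), compound 1 `CCN(CC)CCNC(=O)C1CC(C(CC)(CC)c2ccc(C#CC(C)(C)O)c(C)c2)=CN1CC` gives 3170 nM. Compound 2 `CCN(CC)CCNC(=O)C1CC(C(CC)(CC)c2ccc(C#CC(C)(O)CC)c(C)c2)=CN1CC` gives 2780 nM and compound 3 `CCN(CC)CCNC(=O)C1CC=C(C(CC)(CC)c2ccc(C#CC(O)C3CCCC3)c(C)c2)N1CC` gives 1580 nM, so all three sit within the scatter of one another. Compound 4 `CCN(CC)CCNC(=O)C1CC(C(CC)(CC)c2ccc(CCC(O)(CC)CC)c(C)c2)=CN1CC` differs from compound 1 as follows: 3-ethyl-3-hydroxypentyl in place of 3-hydroxy-3-methylbut-1-yn-1-yl on an aromatic carbon. For the measured compounds named here, the only measured step in this side chain is a 1.1-fold lower number from compound 1 to compound 2 (0.06 log units; within the scatter). That step keeps the triple bond, so the data do not show what removing it does. No shift beyond the scatter is therefore expected in this assay. The estimated step is a 1.3-fold lower number from compound 1 to compound 4 (0.10 log units; within the scatter). Compound 4 is estimated at 2500 nM, with an expected range from 900 nM to 7000 nM.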

Compound 4, half-maximal inhibitory concentration: 3580 nM
For compound 4 the middle estimate is 1.4-fold (0.16 log units) below the measured one; the measured number falls inside the stated range.
By their numbers in this assay, from the lowest: compounds 3, 2, 1 and 4 (each within the scatter of the next, the first and the last beyond it).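

In this assay, putting the saturated 3-ethyl-3-hydroxypentyl in place of 3-hydroxy-3-methylbut-1-yn-1-yl gives a 1.1-fold higher number from compound 1 to compound 4 (0.05 log units; within the scatter) and, against the ethyl-bearing alkyne, a 1.3-fold higher number from compound 2 to compound 4 (0.11 log units; within the scatter) with the hydroxyl group kept in both. So on this aromatic carbon, the triple bond can be lost and the chain lengthened without a shift beyond the scatter. No measured evidence is available to explain this result.

On these data alone, it remains open whether this tolerance holds once the hydroxyl group is replaced, for instance by an amine or a carboxylic acid.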